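Methoxy addition on the lactone series: outlook for compound 4

The compounds below may be only part of what the source reports. "The series", "measured", "known", "first", "only" and "open" are said of these compounds alone.

Compound 1 `COc1ccc(C[C@H]2C(=O)OC[C@@H]2Cc2ccccc2)cc1OC` and compound 2 `COc1cc(C[C@H]2C(=O)OC[C@@H]2Cc2ccccc2)cc(OC)c1OC` share one core; compound 3 `O=C1OC[C@H](Cc2ccc(O)cc2)[C@H]1Cc1ccc(Cl)c(Cl)c1` and compound 4 `COc1cc(C[C@H]2COC(=O)[C@@H]2Cc2ccc(Cl)c(Cl)c2)ccc1O` share another, and the difference between the two cores is not broken down here. In a functional assay on HL-60 cells (Homo sapiens) for cytotoxicity, read by WST assay, with a stated time of 48 h (on this read-out lower numbers stand for an effect already at smaller amounts and higher numbers for an effect only at larger amounts of compound), compound 1 gives a limit of > 100000 nM. Compound 2 likewise gives a limit of > 100000 nM in this assay. The change methoxy in place of hydrogen on an aromatic carbon therefore yields a step that the two limits leave unreadable from compound 1 to compound 2, unreadable since both values sit at the limit of > 100000 nM in this assay, at which 2 of the 3 values shown sit. Compound 3 gives 37000 nM in this assay. Compound 4 carries the same kind of change, (methoxy in place of hydrogen on an aromatic carbon), though the place differs: ortho to a hydroxy group rather than ortho to a methoxy group and meta to a methoxy group. No readable step is available, so the step from compound 3 to compound 4 is expected to be a 1.2-fold lower number from compound 3 to compound 4 (0.09 log units; within the scatter). Compound 4 is estimated at 30000 nM, between 8000 nM and 100000 nM.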

Compound 4, half-maximal effective concentration: 36000 nM
Compound 4: the middle estimate sits 1.2-fold (0.08 log units) below what was measured, and the stated range covers the measured number.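

In this assay methoxy in place of hydrogen on an aromatic carbon gives a 1.0-fold lower number from compound 3 to compound 4 (0.01 log units; within the scatter) when it sits ortho to a hydroxy group. Going by these compounds alone, this is the only readable step for the change, and it comes from one core at one place on the ring. The step on the other core cannot be read, so the data do not show whether the change carries from one core to the other: the limit of > 100000 nM in this assay, at which 2 of the 4 values shown sit.

A single readable step sets no pattern for the series. Still open, on these data alone, is how this assay would read with an amine, a carboxylic acid or a longer chain such as propoxy on that aromatic carbon.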